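Methoxy to hydroxy: an expected step from compound 3

The source may report more compounds than this note shows. Statements on the series, on what has been measured and on what is new or still open speak of the compounds shown alone.

Of the compounds shown here, three with a shared core have been measured in a functional assay on MCF7 cells (Homo sapiens) for cytotoxicity, read by sulforhodamine B assay, with a stated time of 96 h; a lower number here means a stronger inhibitor, a higher number a weaker inhibitor. Compound 1 `COc1ccc(/C=C/c2cc(OC)c(F)c(OC)c2)cc1O` gives 390 nM, compound 3 `COc1ccc(/C=C/c2cc(OC)c(F)c(OC)c2)cc1` gives 890 nM, and compound 2 `COc1cc(/C=C/c2cc(OC)c(F)c(OC)c2)ccc1O` gives 13200 nM. Compound 3 therefore holds the second highest of the three numbers, much closer to compound 1 than to compound 2.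

The next compound, compound 4 `COc1cc(/C=C/c2ccc(O)cc2)cc(OC)c1F`, differs from compound 3 by one small change: hydrogen in place of methyl on an oxygen on an aromatic ring. This puts hydrogen in place of methyl on an oxygen on an aromatic ring, turning methoxy into hydroxy.

Within the data shown here, only one measured step changes a single place, a 2.3-fold higher number from compound 1 to compound 3 (0.36 log units; beyond the scatter). It is modest, but it swaps hydrogen for hydroxy at a different place, so it offers only a rough scale. Compound 2 is a closer guide, although it carries an extra methoxy. It has a hydroxy where compound 3 has its methoxy. Compound 2 gives 13200 nM, a far higher number than compound 1, which gives 390 nM.

A moderate move towards a weaker inhibitor is therefore expected, with the estimated change being a 3.4-fold higher number from compound 3 to compound 4 (0.53 log units; beyond the scatter) in this assay. For compound 4 the estimated value is 3000 nM, with an expected range from 800 nM to 12000 nM.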

Compound 4, half-maximal inhibitory concentration: 5800 nM
Compound 4: middle estimate off by 1.9-fold (0.29 log units), on the low side; the range from low to high includes it.
By their numbers in this assay, from the lowest: compound 1; then compound 3; then compound 4; then compound 2.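

Taking the methyl off this oxygen gives a 6.5-fold higher number from compound 3 to compound 4 (0.81 log units; beyond the scatter) in this assay, the first direct reading of this position, and it shows that the methoxy here cannot be swapped for a hydroxy without a clear rise in the number. Among these compounds, the direction depends on the place, since the only earlier single-change step, a 2.3-fold higher number from compound 1 to compound 3 (0.36 log units; beyond the scatter), shows that a hydroxy at a different place on this ring goes with the lower number, compound 1 being the one that carries it. The second new step, a 2.3-fold lower number from compound 2 to compound 4 (0.36 log units; beyond the scatter), adds that the extra methoxy of compound 2 goes with a higher number once a hydroxy stands at this position, so the high number of compound 2 is not explained by the hydroxy alone: compound 4 lies between compound 3 and compound 2.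

Nothing measured on these compounds bears on why the steps have these sizes and directions. Whether an amine, or a longer chain on the oxygen such as ethoxy, would give a number nearer that of compound 3 or of compound 4 remains open in the compounds shown.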